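Compound 2 Gives Up Its Fluoro

The compounds below may be only part of what the source reports. "The series", "measured", "known", "first", "only" and "open" are said of these compounds alone.

In an ADME assay on Caco-2 cells (Homo sapiens) for permeability, read by LC-MS, in the apical to basolateral direction, with a stated time of 60 min, at pH 6.5 (a higher number here means that the compound crosses the layer faster, a lower number that the compound crosses the layer more slowly), compound 1 (`COC(C)(C)[C@@H](O)C(=O)N1C[C@H]2C[C@H]2[C@H]1C(=O)NCc1cc(Cl)ccc1-n1cnnn1`) gives 3.5 10^-6 cm/s. In the same measurement compound 2 (`O=C(NCc1cc(Cl)ccc1-n1cnnn1)[C@@H]1[C@@H]2C[C@@H]2CN1C(=O)[C@H](O)c1ccccc1F`) gives 2.3 10^-6 cm/s. Among the compounds with values here, the only measured step is a 1.5-fold lower number from compound 1 to compound 2 (0.18 log units; within the scatter), with 2-fluorophenyl in place of 1-methoxy-1-methylethyl, so compound 2 stands within the scatter of compound 1 and the two numbers cannot be ranked.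

Compound 3 (`O=C(NCc1cc(Cl)ccc1-n1cnnn1)[C@@H]1[C@@H]2C[C@@H]2CN1C(=O)[C@H](O)c1ccccc1`) has hydrogen in place of fluoro on an aromatic carbon, ortho to a large group: hydrogen in place of fluoro on an aromatic carbon. The same difference can be read as 2-fluorophenyl to phenyl. Within the data shown here, no measured pair shows this change by itself, so the evidence is indirect. The exchange of the whole group in a 1.5-fold lower number from compound 1 to compound 2 (0.18 log units; within the scatter) stayed within the scatter, and the present change is confined to a single position on that group. No step beyond the scatter is therefore expected in this assay, and the data give no direction. Compound 3 is estimated at 2.5 10^-6 cm/s, with an expected range of 1.2 10^-6 cm/s to 5 10^-6 cm/s. The expected step is a 1.1-fold higher number from compound 2 to compound 3 (0.04 log units; within the scatter).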

Compound 3, apparent permeability: 2.2 10^-6 cm/s
Compound 3: middle estimate off by 1.1-fold (0.06 log units), on the high side; the measured number falls inside the stated range.
By their numbers in this assay, from the lowest: compounds 3, 2 and 1 (each within the scatter of the next).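

In this assay the exchange of fluoro for hydrogen on the aromatic carbon, ortho to a large group, can now be read by itself. It gives a 1.0-fold lower number from compound 2 to compound 3 (0.02 log units; within the scatter) and thus shows that this single change leaves compound 2 and compound 3 indistinguishable, which the earlier exchange of the whole group could not show. The wider exchange, phenyl in place of 1-methoxy-1-methylethyl on a saturated chain carbon bound to a carbonyl carbon and an oxygen on a saturated carbon, gives a 1.6-fold lower number from compound 1 to compound 3 (0.20 log units; within the scatter) and so also stays within the scatter, whether or not the aromatic ring carries the fluoro, while the data offer no explanation for either result.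

The compounds shown leave open whether an amine or a carboxylic acid on this same aromatic carbon would produce a step beyond the scatter. They also leave open whether a longer chain in place of the phenyl or 1-methoxy-1-methylethyl group on the saturated chain carbon would separate from compound 1, compound 2 and compound 3 in this assay.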